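This account rests on a few compounds, and the source may have more. Where it says the series, first, only, none or still open, it means among the compounds named here.

Measured so far in an ADME assay on MCF7 cells (Homo sapiens) for cytotoxicity, with a stated time of 72 h; on this read-out higher numbers stand for weaker inhibition and lower numbers for stronger inhibition:
- compound 1 `Oc1ccccc1CNc1ncnc2c1ncn2C1CCCCO1` gives > 100000 nM as a limit
- compound 2 `Oc1cccc(CNc2ncnc3c2ncn3C2CCCCO2)c1` gives > 100000 nM as a limit
- compound 3 `Oc1ccccc1CNc1ncnc2c1ncn2C1CCCO1` gives > 100000 nM as a limit

Compound 3 has no number on this read-out, only the limit > 100000 nM of the assay. Going by the values given here, the series so far consists of the limit of > 100000 nM in this assay, at which 3 of the 3 values shown sit, and offers no ranking. Next is compound 4 `Oc1cccc(CNc2ncnc3c2ncn3C2CCCO2)c1`, with the change (3-hydroxyphenyl in place of 2-hydroxyphenyl on a saturated chain carbon bound to a nitrogen on an aromatic ring), that is, 3-hydroxyphenyl in place of 2-hydroxyphenyl on a saturated chain carbon bound to a nitrogen on an aromatic ring. The same exchange was made on the core of compound 1, as a step that the two limits leave unreadable from compound 1 to compound 2, and it gives no measurable size. The other measured step, a step that the two limits leave unreadable from compound 1 to compound 3, exchanges oxan-2-yl for oxolan-2-yl and is equally unreadable. Neither step supports an expected change in this assay, so no direction is expected and nothing beyond the usual scatter. The expected step is a number no higher from compound 3 to compound 4 (the limit leaves the size open) and it is only an estimate. Compound 4 is most likely to report the same limit again. As a number, compound 4 is estimated at 100000 nM, with an expected range from 50000 nM to 200000 nM.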

Compound 4, half-maximal inhibitory concentration: > 100000 nM
Compound 4 ended at the assay's limit (the forecaster's own chance of this, stated with the estimate: 85%); the middle value sits exactly at the limit.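

The steps from compound 3 to compound 4 and from compound 2 to compound 4 cannot be read in this assay, since all four compounds share one result: the limit of > 100000 nM in this assay, at which 4 of the 4 values shown sit.

The compounds shown leave open whether either exchange, hydroxyphenyl or oxolan-2-yl, alters this read-out at all.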